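From compound 3 to compound 4: a methoxymethoxy swap

This account rests on a few compounds, and the source may have more. Where it says the series, first, only, none or still open, it means among the compounds named here.

In a functional assay on MCF7 cells (Homo sapiens) for inhibition, read by MTT assay, with a stated time of 3 days (on this read-out higher numbers stand for weaker inhibition and lower numbers for stronger inhibition), compound 1 (`C/C=C/COc1cc(/C=C\c2cc(OC)c(OC)c(OC)c2)ccc1OC`) gives 5400 nM, compound 3 (`COc1ccccc1/C=C/CCCOc1cc(/C=C\c2cc(OC)c(OC)c(OC)c2)ccc1OC`) gives 21000 nM and compound 2 (`COc1ccc(COc2cc(/C=C\c3cc(OC)c(OC)c(OC)c3)ccc2OC)cc1`) gives 48000 nM. Compound 3 therefore stands in the middle of the three numbers. Compound 4 (`COCOc1ccccc1/C=C/CCCOc1cc(/C=C\c2cc(OC)c(OC)c(OC)c2)ccc1OC`) carries 2-(methoxymethoxy)phenyl in place of 2-methoxyphenyl: methoxy in place of hydrogen on a saturated chain carbon bound to an oxygen on an aromatic ring.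

Among the measured compounds shown here, three measured steps bear on this only loosely, as each exchanges a whole group: an 8.9-fold higher number from compound 1 to compound 2 (0.95 log units; beyond the scatter), a 3.9-fold higher number from compound 1 to compound 3 (0.59 log units; beyond the scatter) and a 2.3-fold lower number from compound 2 to compound 3 (0.36 log units; beyond the scatter). All are modest, and none tests a change this small. No step beyond the scatter is therefore expected in this assay, with at most a slight drift towards a higher number. The expected step is a 1.2-fold higher number from compound 3 to compound 4 (0.08 log units; within the scatter). For compound 4 the estimated value is 25000 nM, with an expected range of 10000 nM to 60000 nM.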

Compound 4, half-maximal inhibitory concentration: 4400 nM
For compound 4 the middle estimate is 5.7-fold (0.75 log units) above the measured one; measured number outside the range, below it.
By their numbers in this assay, from the lowest: compounds 4 and 1 (each within the scatter of the next); then compound 3; then compound 2.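

In this assay, methoxy in place of hydrogen on a saturated chain carbon bound to an oxygen on an aromatic ring gives a 4.8-fold lower number from compound 3 to compound 4 (0.68 log units; beyond the scatter) and so moves the number towards stronger inhibition. This shows that a change of only two heavy atoms at the far end of the side chain can shift this read-out, which the whole-group exchanges among compound 1, compound 2 and compound 3 could not show. No measurement on hand accounts for this step.

On these data alone, it remains open whether this gain is specific to 2-(methoxymethoxy)phenyl. A hydroxy group or a longer ether chain at this place would test that.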